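Adding an Aminobutyl Side Chain to Compound 1

The source may hold more compounds than are shown below. What is called first, only, known or untested is meant among the compounds shown, and "the series" means these compounds.

Measured so far: in a functional assay on the whole organism (Tail, strain ICR) with Mus musculus as the target, in the tail flick test, with a stated time of 120 min, at a dose of 25 umol/kg by the oral route (on this read-out lower numbers stand for a weaker effect and higher numbers for a stronger effect at the one dose given), compound 1 `C[C@H](NC(=O)CN(c1nc(Cl)nc2[nH]cnc12)C1CC1)C(=O)O` gives 28.4%. Compound 2 `CC(C)(C)OC(=O)NCCCC[C@H](NC(=O)CN(c1ncnc2c1ncn2C1CCCCO1)C1CC1)C(=O)OCc1ccccc1` gives 28.4%. Compound 3 `NC(=O)C[C@H](NC(=O)CN(c1ncnc2c1ncn2C1CCCCO1)C1CC1)C(=O)OCc1ccccc1` gives 29.2%.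

Compound 1 stands level with compound 2 at the digits shown, the two together being the lowest of the three numbers; compound 3 lies furthest away, yet that gap is within the scatter, so the three read as one level.

Compound 4 `NCCCC[C@H](NC(=O)CN(c1nc(Cl)nc2[nH]cnc12)C1CC1)C(=O)O` differs from compound 1 by 3-aminopropyl in place of hydrogen on a saturated chain carbon, two bonds along the chain from an amide-type nitrogen and a carbonyl carbon. Within the data shown here, the one measured step at that place on the chain is a number 0.8 percentage points higher from compound 2 to compound 3 (within the scatter), which changed the group there and stayed within the scatter. On that basis no step beyond the scatter is expected, a number 0.6 percentage points higher from compound 1 to compound 4 (within the scatter). Compound 4 is estimated at 29%, expected between 14% and 44%.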

Compound 4, a percentage reported as activity, at one dose (the size of the read-out at that dose, not a potency): 16.4%
Compound 4: middle estimate off by 12.6 percentage points, on the high side, and the stated range covers the measured number.
By their numbers in this assay, from the lowest: compound 4; then compounds 1, 2 and 3 (each within the scatter of the next).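

In this assay, this place on the chain proves sensitive to change: 3-aminopropyl in place of hydrogen gives a number 12 percentage points lower from compound 1 to compound 4 (beyond the scatter). The earlier step at this place, a number 0.8 percentage points higher from compound 2 to compound 3 (within the scatter), swapped one group for another and gave no sign of this sensitivity. Nothing available accounts for the drop.

The compounds shown leave open whether the lower number goes with the amine of 3-aminopropyl or with the carbon chain that carries it. A plain propyl chain, or a carboxylic acid in place of the amine, would help tell these apart.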